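The source may report more compounds than this note shows. Statements on the series, on what has been measured and on what is new or still open speak of the compounds shown alone.

Among the measured compounds shown here, compound 2 `N#C/C(=C\N1CCN(C(=O)c2ccco2)C1=S)C(N)=O` has the highest of the two numbers so far in a functional assay on RPMI8266 cells (Homo sapiens) for inhibition, read by sulforhodamine B assay, with a stated time of 48 h (on this read-out higher numbers stand for weaker inhibition of growth and lower numbers for stronger inhibition of growth), where compound 2 gives 12400 nM. For the measured compounds named here, its only neighbour, compound 1 `N#C/C(=C\N1CCN(C(=O)c2ccco2)C1=S)C(=O)Nc1ccc(Cl)cc1`, gives 10500 nM in this assay; the change a 1.2-fold higher number from compound 1 to compound 2 (0.07 log units; within the scatter) lies within the scatter. Compound 3 `N#C/C(=C\N1CCN(C(=O)c2ccco2)C1=S)C(=O)c1ccccc1` differs from compound 2 by phenyl in place of amino on a carbonyl carbon, a carbamoyl-to-benzoyl swap. Going by the values given here, the one measured step touches a different position, so it bears only loosely; a similar removal of a donor changed little, and no step beyond the scatter is expected here, a 1.1-fold lower number from compound 2 to compound 3 (0.05 log units; within the scatter). Compound 3 is therefore estimated at 11000 nM, between 4000 nM and 30000 nM.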

Compound 3, concentration for 50% growth inhibition: 5600 nM
For compound 3 the middle estimate is 2.0-fold (0.29 log units) above the measured one; low and high end bracket the measured number.
By their numbers in this assay, from the lowest: compounds 3, 1 and 2 (each within the scatter of the next, the first and the last beyond it).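

In this assay, among the compounds shown here, benzoyl in place of carbamoyl gives a 2.2-fold lower number from compound 2 to compound 3 (0.35 log units; beyond the scatter) and is the first step in this small set to pass beyond the scatter. Phenyl in place of (4-chlorophenyl)amino on the same carbonyl carbon gives a 1.9-fold lower number from compound 1 to compound 3 (0.27 log units; within the scatter) and stays within the scatter, so compound 3 is set apart only from compound 2. Nothing measured here explains this difference.

As far as these compounds go, whether an ethyl group or a pyridine ring on this carbonyl carbon would give a lower or a higher number remains open.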